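Removing the benzyloxy group from compound 1

This account rests on a few compounds, and the source may have more. Where it says the series, first, only, none or still open, it means among the compounds named here.

Compound 1 `O=[N+]([O-])c1cc(OCc2ccccc2)ccc1CNc1cc(C(F)(F)F)cc2[nH]ncc12` gives 55% in an assay for inhibition of Tryptophan 2,3-dioxygenase (Homo sapiens), with stated times of 10 min and 60 min, tested at 100 uM (a higher number here means a stronger effect of the compound at the concentration tested, a lower number a weaker effect), the higher of the two numbers recorded there; compound 2 `OC1CCCC(Nc2cccc(CNc3cc(C(F)(F)F)cc4[nH]ncc34)c2)C1` gives 23% in this assay, a value that lies beyond the scatter below it. Compound 3 `O=[N+]([O-])c1ccccc1CNc1cc(C(F)(F)F)cc2[nH]ncc12` has not yet been measured. It differs from compound 1 by hydrogen in place of benzyloxy on an aromatic carbon. Among the compounds with values here, no step between measured compounds covers such a change, so its size is uncertain, but a loss of inhibition beyond the scatter is expected. The step from compound 1 to compound 3 is estimated at a number 20 percentage points lower from compound 1 to compound 3 (beyond the scatter). Compound 3 is thus expected to give about 35%, with a range from 10% to 60%.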

Compound 3, a percentage reported as inhibition, at one concentration (the size of the read-out at that concentration, not a potency): 95%
Beside the measured number, compound 3's estimate is 60 percentage points below it; the measured number lies above the stated range.
By their numbers in this assay, from the lowest: compound 2; then compound 1; then compound 3.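

In this assay hydrogen in place of benzyloxy on this aromatic carbon, meta to a nitro group, gives a number 40 percentage points higher from compound 1 to compound 3 (beyond the scatter) and so shows that the benzyloxy group is not needed for inhibition at this position. The bare carbon serves better here than this large group. No independent measurement bears on the reason for the gain. As far as these compounds go, it remains open whether a methoxy group, an amine or a fluorine atom on this carbon would keep the inhibition. Also open, from the compounds shown here alone, is how a nitrile or a carboxylic acid would compare with the nitro group.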